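Chloro to trifluoromethyl on the shared core: compound 4

A few compounds are considered here, and "the series" means these few. Any claim that something is new, unique, unknown or untested is made for them only; others in the source may bear on it.

Measured so far in a functional assay on OVCAR-8 cells (Homo sapiens) for inhibition, read by sulforhodamine B assay, with a stated time of 48 h; on this read-out higher numbers stand for weaker inhibition of growth and lower numbers for stronger inhibition of growth:
Compound 1, `O=C(Nc1cccc(-n2cc(-c3ccncc3)c(-c3ccc(Cl)c(O)c3)n2)c1)Nc1ccc(Cl)c(Cl)c1`, gives 1210 nM.
Compound 2, `O=C(Nc1cccc(-n2cc(-c3ccncc3)c(-c3ccc(Cl)c(O)c3)n2)c1)Nc1cc(C(F)(F)F)cc(C(F)(F)F)c1`, gives 563 nM.
Compound 3, `COc1cc(-c2nn(-c3cccc(NC(=O)Nc4cccc(C(F)(F)F)c4)c3)cc2-c2ccncc2)ccc1Cl`, gives 739 nM.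

Compound 1 carries the highest number of the three. Compound 3 stands nearest, its number lower by an amount within the scatter, so the two cannot be ordered; compound 3 also differs from compound 1 in more than one place. Compound 2 stands furthest, its number lower by an amount beyond the scatter. Both compound 2 and compound 3 carry trifluoromethyl where compound 1 carries chloro.

Compound 4, `O=C(Nc1cccc(-n2cc(-c3ccncc3)c(-c3ccc(Cl)c(O)c3)n2)c1)Nc1ccc(Cl)c(C(F)(F)F)c1`, is not yet measured. It differs from compound 1 in one place: trifluoromethyl in place of chloro on an aromatic carbon. Among the compounds with values here, no measured pair shows exactly this step, so the expectation rests on the numbers of compound 2 and compound 3 against compound 1. The step of a 1.7-fold lower number from compound 1 to compound 4 (0.24 log units; within the scatter) is expected to be a modest lowering of the number, near the edge of the scatter rather than clearly beyond it. Compound 4 is therefore estimated at 700 nM, with a range from 300 nM to 1600 nM.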

Compound 4, concentration for 50% growth inhibition: 759 nM
Beside the measured number, compound 4's estimate is 1.1-fold (0.04 log units) below it, within the range that was stated.
By their numbers in this assay, from the lowest: compounds 2, 3, 4 and 1 (each within the scatter of the next, the first and the last beyond it).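

In this assay, within the data shown here, trifluoromethyl in place of chloro gives a 1.6-fold lower number from compound 1 to compound 4 (0.20 log units; within the scatter) and is the first step that changes only one place. At this position on the ring, 3,4-dichlorophenyl and 4-chloro-3-(trifluoromethyl)phenyl therefore cannot be ordered, even though the entering group has 4 heavy atoms against 1 for chloro. No available measurement explains this result.

As far as these compounds go, whether any group at this position can move the number beyond the scatter remains open, for example a methoxy group, an amine or a carboxylic acid. Also open, from the compounds shown here alone, is whether the same exchange would read alike at the remaining chloro on this ring, or with the shared core changed elsewhere.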